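Swapping one aryl group on an inactive compound

A few compounds are considered here, and "the series" means these few. Any claim that something is new, unique, unknown or untested is made for them only; others in the source may bear on it.

In a functional assay on MCF7 cells (Homo sapiens) for antiproliferative activity, read by MTT assay, with a stated time of 72 h (a higher number here means a weaker inhibitor, a lower number a stronger inhibitor), compound 3 `CCCNC(=O)c1cc(Oc2ccc(NC(=O)c3nn(-c4ccc(Br)cc4F)c(=O)cc3C)cc2F)ccn1` is reported as "not active" (no number reported) and has no number, so it cannot be placed exactly beside its relatives. In this assay compound 1 `CCCNC(=O)c1cc(Oc2ccc(NC(=O)c3nn(-c4ccc(C)cc4)c(=O)cc3C)cc2F)ccn1` gives 34600 nM and compound 2 `CCNC(=O)c1cc(Oc2ccc(NC(=O)c3nn(-c4ccccc4C)c(=O)cc3C)cc2)ccn1` gives 44300 nM as measured values. Compound 4 `CCCNC(=O)c1cc(Oc2ccc(NC(=O)c3nn(-c4ccccc4C)c(=O)cc3C)cc2F)ccn1` has 2-methylphenyl in place of 4-bromo-2-fluorophenyl on an aromatic nitrogen. Compound 2 carries the same 2-methylphenyl and reads 44300 nM in this assay so a move toward stronger inhibition is expected, from no number to a weak but measurable value. The estimated value for compound 4 is 40000 nM within an expected range of 15000 nM to 90000 nM and thus still weak.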

Compound 4, half-maximal inhibitory concentration: 39600 nM
Estimate against measurement, compound 4: 1.0-fold (0.00 log units) above, and the stated range covers the measured number.
By their numbers in this assay, from the lowest: compounds 1, 4 and 2 (each within the scatter of the next).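

Compound 3 is reported as not active, while compound 4, with 2-methylphenyl in place of 4-bromo-2-fluorophenyl, has a measurable though weak value in this assay and so can be compared. Changing 4-methylphenyl to 2-methylphenyl gives a 1.1-fold higher number from compound 1 to compound 4 (0.06 log units; within the scatter) and so the place of the methyl on this ring makes no readable difference here. Nothing shown explains either observation.

Still open, going by these compounds, is whether the bromine or the fluorine goes with the not-active report. On these data alone, it is also open whether an aryl ring carrying an amine or a carboxylic acid would read differently.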